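The source may report more compounds than this note shows. Statements on the series, on what has been measured and on what is new or still open speak of the compounds shown alone.

Measured so far:

- compound 1, `CCCN(c1nc(-c2ccc(Cl)cc2OC)n(C)n1)C(CC)c1ccc(C(F)(F)F)cc1`, gives 12 nM in an in vitro assay on Ltk- cells for binding affinity to corticotropin-releasing factor receptor 1 (Homo sapiens); a higher number here means a weaker inhibitor, a lower number a stronger inhibitor
- compound 2, `CCCCC(CC)N(OCCC)c1nc(-c2ccc(Cl)cc2OC)n(C)n1`, gives 280 nM in this assay
- compound 3, `CCCN(c1nc(-c2ccc(Cl)cc2OC)n(C)n1)C(C(C)C)C(C)C`, gives 910 nM in this assay

All three compounds share the same core and differ only in what hangs on the nitrogen attached to that core. Compound 3 has the highest number of the three, which in this assay means the weakest binding: its closest neighbour is compound 2, whose number is lower by a gap beyond the usual scatter, and compound 1 lies much further down still.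

Compound 4, `CCCCC(CC)N(CCC)c1nc(-c2ccc(Cl)cc2OC)n(C)n1`, has not been measured. It keeps every atom of compound 3 but joins them differently: 1-ethylpentyl in place of 1-isopropyl-2-methylpropyl on a nitrogen on an aromatic ring. Compound 2 carries this same 1-ethylpentyl group on the nitrogen, though with a different second neighbour there, and its value of 280 nM already sits well under that of compound 3. For compound 4 the step of a 23-fold lower number from compound 3 to compound 4 (1.36 log units; beyond the scatter) is expected to be a clear drop, beyond the scatter. Compound 4 is estimated at 40 nM, within a range of 10 nM to 160 nM.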

Compound 4, inhibition constant: 46 nM
Beside the measured number, compound 4's estimate is 1.2-fold (0.06 log units) below it; the range from low to high includes it.
By their numbers in this assay, from the lowest: compound 1; then compound 4; then compound 2; then compound 3.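

Joining the same atoms differently is enough to shift binding: 1-ethylpentyl in place of 1-isopropyl-2-methylpropyl on the nitrogen gives a 20-fold lower number from compound 3 to compound 4 (1.30 log units; beyond the scatter) in this assay, so how these carbons are arranged matters, not only how many there are. Going by these compounds alone, with 1-ethylpentyl kept, propyl in place of propoxy gives a 6.1-fold lower number from compound 2 to compound 4 (0.78 log units; beyond the scatter), a first clean reading of the second group on that nitrogen. Butyl in place of 4-(trifluoromethyl)phenyl on the saturated chain carbon gives a 3.8-fold higher number from compound 1 to compound 4 (0.58 log units; beyond the scatter), a modest step that shows an open chain can come fairly close to the aryl group there.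

Nothing shown here explains why any of these changes moves the number. As far as these compounds go, how a longer chain such as butyl, or a cyclopropylmethyl group, would compare with propyl on that nitrogen remains open.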